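The compounds below may be only part of what the source reports. "The series", "measured", "known", "first", "only" and "open" are said of these compounds alone.

Measured compounds and their values in an assay on brain for displacement of a labelled ligand from Adrenergic receptor alpha-1 (Rattus norvegicus); a lower number here means a stronger inhibitor, a higher number a weaker inhibitor:
compound 1, `CCOCCOC1CCN(c2nc(N)c3cc(OC)c(OC)cc3n2)CC1`: 1.81 nM
compound 2, `COc1cc2nc(N3CCC(OCCOC(C)C)CC3)nc(N)c2cc1OC`: 0.67 nM
compound 3, `COc1cc2nc(N3CCC(OCC(C)OC)CC3)nc(N)c2cc1OC`: 1.41 nM

All three share one core and differ only in the side chain on the piperidine oxygen. Compound 1 and compound 3 are built from the same atoms joined differently: 1-methoxyethyl in place of ethoxymethyl on a saturated chain carbon bound to an oxygen on a saturated carbon. The step between them, a 1.3-fold lower number from compound 1 to compound 3 (0.11 log units; within the scatter), lies within the scatter, so nothing is made of their order. Compound 1 and compound 2 differ by methyl in place of hydrogen on a saturated chain carbon bound to an oxygen on a saturated carbon and a saturated chain carbon, and that single added methyl gives a 2.7-fold lower number from compound 1 to compound 2 (0.43 log units; beyond the scatter). Compound 2 and compound 3 are separated by a 2.1-fold higher number from compound 2 to compound 3 (0.32 log units; beyond the scatter).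

Compound 4, `COc1cc2nc(N3CCC(OCC(C)(C)OC)CC3)nc(N)c2cc1OC`, is not yet measured in this assay. It differs from compound 3 by methyl in place of hydrogen on a saturated chain carbon bound to an oxygen on a saturated carbon and two saturated chain carbons. Among the compounds with values here, this is the same kind of change as the one from compound 1 to compound 2, but not the same: in the earlier pair the carbon that takes the methyl is bound to an oxygen on a saturated carbon and a saturated chain carbon, whereas in compound 4 it is bound to an oxygen on a saturated carbon and two saturated chain carbons. Within the data shown here, only one instance of this kind of change is measured, so the expectation rests on it alone. Starting from compound 3 at 1.41 nM, a step of a 1.6-fold lower number from compound 3 to compound 4 (0.19 log units; within the scatter) is expected in this assay, somewhat smaller than the one seen from compound 1 to compound 2 because a 2.7-fold lower number from compound 1 to compound 2 (0.43 log units; beyond the scatter) was itself only modest and the surroundings are not identical. Compound 4 is therefore estimated at 0.9 nM, with a plausible range from 0.35 nM to 2.5 nM.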

Compound 4, inhibition constant: 1.14 nM
Compound 4: middle estimate off by 1.3-fold (0.10 log units), on the low side; the range from low to high includes it.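

In this assay, the added methyl gives a 1.2-fold lower number from compound 3 to compound 4 (0.09 log units; within the scatter), and the two measured instances of this change cannot be told apart: the same change on two cores in this assay, a 2.7-fold lower number (0.43 log units; beyond the scatter) from compound 1 to compound 2 and a 1.2-fold lower number (0.09 log units; within the scatter) from compound 3 to compound 4, 2.2-fold (0.34 log units) apart, within the scatter of two such steps

Within the data shown here, this shows no evidence that the change behaves differently on the two cores, but it does not show that the step carries over at a fixed size, as only the step from compound 1 to compound 2 lies beyond the scatter and two pairs are a thin basis for any rule. Compound 4 also cannot be separated from either of the other two compounds, with a 1.7-fold higher number from compound 2 to compound 4 (0.23 log units; within the scatter) and a 1.6-fold lower number from compound 1 to compound 4 (0.20 log units; within the scatter), so its side chain can be placed neither with the compound 2 side chain nor with that of compound 1.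

All four side chains on the piperidine oxygen are ethers, so the compounds shown leave open how a hydroxyl, a primary amine, a carboxylic acid or a longer alkoxy chain would fare in this position. They also leave open whether the same methyl change on a third side chain would give a step nearer the larger or the smaller of the two seen so far.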